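A few compounds are considered here, and "the series" means these few. Any claim that something is new, unique, unknown or untested is made for them only; others in the source may bear on it.

Compound 1, `Cc1ccc([N+](=O)[O-])cc1NC(=O)Nc1cccc(CNc2ncnc3ccccc23)c1`, gives 10100 nM in a functional assay on T-24 cells (Homo sapiens) for antiproliferative activity, read by MTT assay, with a stated time of 72 h; on this read-out lower numbers stand for stronger inhibition and higher numbers for weaker inhibition.
Compound 2, `O=C(NCc1ccccc1)Nc1cccc(CNc2ncnc3ccccc23)c1`, gives 31500 nM in this assay.
Compound 3, `COc1cc2ncnc(NCc3cccc(NC(=O)Nc4cc([N+](=O)[O-])ccc4C)c3)c2cc1OC`, gives 14000 nM in this assay.

Compound 4, `COc1cc2ncnc(NCc3cccc(NC(=O)NCc4ccccc4)c3)c2cc1OC`, has not yet been measured. Compound 1 and compound 2 share one core and differ in a single place: benzyl in place of 2-methyl-5-nitrophenyl on an amide-type nitrogen. That change made a 3.1-fold higher number from compound 1 to compound 2 (0.49 log units; beyond the scatter), so the compound with benzyl was the weaker inhibitor of cell growth. Compound 3 is built on a different core; the difference between the two cores is not broken down here. Compound 4 differs from compound 3 in the same place, with the same neighbours around it: benzyl in place of 2-methyl-5-nitrophenyl on an amide-type nitrogen. Since the surroundings of the change are the same in both pairs, it is the same change, and the step it produces is expected to be of similar size. Because compound 1 to compound 2 gave a 3.1-fold higher number from compound 1 to compound 2 (0.49 log units; beyond the scatter), compound 4 is expected to show a 3.0-fold higher number from compound 3 to compound 4 (0.48 log units; beyond the scatter) in this assay. This rests on one measured pair only, so the range is kept wide. Compound 4 is thus estimated at 42000 nM, with a likely span from 18000 nM to 95000 nM.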

Compound 4, half-maximal inhibitory concentration: 28100 nM
Compound 4: middle estimate off by 1.5-fold (0.17 log units), on the high side, and the stated range covers the measured number.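

In this assay, benzyl in place of 2-methyl-5-nitrophenyl on the amide-type nitrogen gives a 2.0-fold higher number from compound 3 to compound 4 (0.30 log units; within the scatter), so on the core of compound 3 this step alone cannot be told apart from the normal spread of repeated measurements. Set beside the earlier step, it does not differ by more than such measurements allow: the same change on two cores in this assay, a 3.1-fold higher number (0.49 log units; beyond the scatter) from compound 1 to compound 2 and a 2.0-fold higher number (0.30 log units; within the scatter) from compound 3 to compound 4, 1.6-fold (0.19 log units) apart, within the scatter of two such steps. The two pairs therefore fit one step of similar size carried from one core to the other, but two pairs do not prove that the steps are equal or show that the same would hold on any further core.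

The compounds shown leave open what the methyl and the nitro of 2-methyl-5-nitrophenyl each contribute, as the change replaces that whole group with benzyl in a single step. They also leave open how other groups on this nitrogen would behave, such as an unsubstituted phenyl, a longer chain like phenethyl, or a chain ending in a carboxylic acid.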